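The compounds below may be only part of what the source reports. "The series", "measured", "known", "first", "only" and "open" are said of these compounds alone.

Measured so far:
- Compound 1 `CCCCCCC(C)(O)/C(=C/B1OC(C)(C)C(C)(C)O1)CCC`: 33900 nM
- Compound 2 `CCCCC(C)(O)/C(=C/B1OC(C)(C)C(C)(C)O1)CCC`: 54600 nM
- Compound 3 `CCCCCCCC/C(=C\B1OC(C)(C)C(C)(C)O1)C(O)(c1ccccc1)C1CC1`: 6360 nM

In a functional assay on ARH-77 cells (Homo sapiens) for cytotoxicity, read by MTT assay, with a stated time of 72 h (on this read-out lower numbers stand for stronger inhibition and higher numbers for weaker inhibition), compound 1 gives 33900 nM, the second highest of the three numbers. Among the measured compounds shown here, its nearest neighbour is compound 2, whose value of 54600 nM lies within the scatter of it; the furthest is compound 3, whose value of 6360 nM lies beyond the scatter on the lower side, though compound 3 differs from compound 1 in more than one place and no single step connects them.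

Compound 4 `CCCCCCCC/C(=C\B1OC(C)(C)C(C)(C)O1)C(C)(O)CCCCCC` has not yet been measured in this assay. It differs from compound 1 by pentyl in place of hydrogen on a saturated chain carbon, three bonds along the chain from a double-bonded chain carbon. For the measured compounds named here, the only measured step that bears on a change of chain length is a 1.6-fold higher number from compound 1 to compound 2 (0.21 log units; within the scatter), which removed carbon rather than adding it and stayed within the scatter. Going by the values given here, the step to compound 4 adds a longer chain, and the data give no single-change step for such an addition. The estimate for compound 4 is therefore a cautious one, a 1.7-fold lower number from compound 1 to compound 4 (0.23 log units; within the scatter), with compound 4 expected to give about 20000 nM in this assay, within a range from 6000 nM to 60000 nM.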

Compound 4, half-maximal inhibitory concentration: 79100 nM
The estimate for compound 4 lay 4.0-fold (0.60 log units) below the measured number; measured number outside the range, above it.
By their numbers in this assay, from the lowest: compound 3; then compounds 1, 2 and 4 (each within the scatter of the next, the first and the last beyond it).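

In this assay, pentyl in place of hydrogen on a saturated chain carbon, three bonds along the chain from a double-bonded chain carbon, gives a 2.3-fold higher number from compound 1 to compound 4 (0.37 log units; beyond the scatter), a modest weakening. Among the compounds shown here, this is the first single change here to pass beyond the scatter, whereas the only earlier step, a 1.6-fold higher number from compound 1 to compound 2 (0.21 log units; within the scatter), lies at another place on the chain and stays within it. No measurement available here explains this shift.

The compounds shown leave open whether a shorter group at this carbon, such as ethyl or propyl, would already raise the number, or whether a longer chain than pentyl would raise it further. They also leave open how an amine or a carboxylic acid at the end of the pentyl chain would read in this assay.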